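Carboxymethyl to isopropoxycarbonyl: compound 2 and compound 4

The source may hold more compounds than are shown below. What is called first, only, known or untested is meant among the compounds shown, and "the series" means these compounds.

Going by the values given here, in a functional assay on the whole organism for inhibition, with Rattus norvegicus as the target, read by paw edema, with stated times of 1 h and 3 h (a lower number here means that less compound is needed, a higher number that more compound is needed for the effect), compound 2 (`C/C(=N\OCCC(=O)O)c1ccc(Cl)cc1`) gives 80 mg/kg, the highest number so far, and compound 3 (`C/C(=N\OC(C)C(=O)O)c1ccc(Cl)cc1`) gives 55 mg/kg. The two do not separate: a 1.5-fold lower number from compound 2 to compound 3 (0.16 log units; within the scatter). That step is the only one measured, and it stays within the acid chains. Compound 1 (`COC(=O)CO/N=C(\C)c1ccc(Br)cc1`), the only ester measured, gives 14 mg/kg, clearly under compound 2, although it differs from compound 2 in more than one place.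

Compound 4 (`C/C(=N\OCC(=O)OC(C)C)c1ccc(Cl)cc1`) has isopropoxycarbonyl in place of carboxymethyl on a saturated chain carbon bound to an oxygen. Judging by compound 1 at 14 mg/kg, a drop beyond the scatter is expected in this assay. The expected step is a 3.1-fold lower number from compound 2 to compound 4 (0.49 log units; beyond the scatter). For compound 4 the estimate is 26 mg/kg, with an expected range of 10 mg/kg to 70 mg/kg.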

Compound 4, dose for half-maximal effect: 50 mg/kg
The estimate for compound 4 lay 1.9-fold (0.28 log units) below the measured number, and the stated range covers the measured number.
By their numbers in this assay, from the lowest: compound 1; then compounds 4, 3 and 2 (each within the scatter of the next).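

In this assay, isopropoxycarbonyl in place of carboxymethyl gives a 1.6-fold lower number from compound 2 to compound 4 (0.20 log units; within the scatter). Going by these compounds alone, this is the first one-place step that leaves the acid chains, and it does not separate the pair, so on this core the ester at this place alone gives no step beyond the scatter. Nothing measured here offers an explanation for this result.

On these data alone, whether a primary amide or a longer chain on the same saturated chain carbon would separate from compound 2 remains open. Which of its several differences sets compound 1 apart from compound 2 also remains open.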